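The source may report more compounds than this note shows. Statements on the series, on what has been measured and on what is new or still open speak of the compounds shown alone.

Of the compounds shown here, three built on a shared core have been tested in a functional assay on A549 cells (Homo sapiens) for inhibition, read by MTT assay, with a stated time of 48 h; on this read-out higher numbers stand for weaker inhibition and lower numbers for stronger inhibition. Compound 1 `Cn1c(/C=C2\SC(=O)N(CC(=O)Nc3cc(C(C)(C)C)on3)C2=O)nc2ccccc21` gives 15300 nM in this assay. Compound 2 `CC1CN(C(=O)CN2C(=O)S/C(=C\c3nc4ccccc4n3C)C2=O)CC(C)O1` gives 29400 nM in this assay. For compound 3 `CC1CN(C(=O)CN2C(=O)S/C(=C\c3nc4ccccc4n3C(C)C)C2=O)CC(C)O1` this assay reports only a limit, > 50000 nM, and not a number.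

Two single changes connect the measured compounds. Going a 1.9-fold lower number from compound 2 to compound 1 (0.28 log units; within the scatter), the change is (5-(tert-butyl)-1,2-oxazol-3-yl)amino in place of 2,6-dimethylmorpholin-4-yl on a carbonyl carbon. Going an at least 1.7-fold higher number from compound 2 to compound 3 (0.23 log units; that floor lies within the scatter), the change is isopropyl in place of methyl on an aromatic nitrogen; as compound 3 stands at the limit (the limit of > 50000 nM in this assay, at which 1 of the 3 values shown sits), the true size of that step is unknown.

Compound 4 `CC(C)n1c(/C=C2\SC(=O)N(CC(=O)Nc3cc(C(C)(C)C)on3)C2=O)nc2ccccc21` has not yet been tested in this assay. It differs from compound 3 by (5-(tert-butyl)-1,2-oxazol-3-yl)amino in place of 2,6-dimethylmorpholin-4-yl on a carbonyl carbon. This is the same change that turns compound 2 into compound 1, made on the same kind of place, as the two place descriptions agree word for word. The two cores differ by isopropyl in place of methyl on an aromatic nitrogen, the only difference between them.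

On this basis compound 4 is expected to give about 45000 nM in this assay, with a likely range from 15000 nM to 150000 nM. The expected step of an at least 1.1-fold lower number from compound 3 to compound 4 (0.04 log units; that floor lies within the scatter) is meant as an estimate only. It rests on the earlier step of a 1.9-fold lower number from compound 2 to compound 1 (0.28 log units; within the scatter) lying within the scatter, and on compound 3 sitting at the limit (the limit of > 50000 nM in this assay, at which 1 of the 3 values shown sits), so compound 4 may well return only a limit too.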

Compound 4, half-maximal inhibitory concentration: > 50000 nM
Compound 4 was reported as a limit; the forecaster's own chance of this, stated with the estimate: 55%; middle value at least 1.1-fold (0.04 log units) away from the limit.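

In this assay compound 4 returns only a limit, > 50000 nM, and not a number, so carrying (5-(tert-butyl)-1,2-oxazol-3-yl)amino in place of 2,6-dimethylmorpholin-4-yl over to the isopropyl core gives a step that cannot be read, because compound 3 and compound 4 both stop at the limit: the limit of > 50000 nM in this assay, at which 2 of the 4 values shown sit.

The other change, isopropyl in place of methyl on an aromatic nitrogen, can be read on the core of compound 1, an at least 3.2-fold higher number from compound 1 to compound 4 (0.51 log units; beyond the scatter), which shows weaker inhibition with isopropyl on that core. This does not show whether the change has the same size on both cores, or a different one: the same change on two cores in this assay, an at least 1.7-fold higher number (0.23 log units; that floor lies within the scatter) from compound 2 to compound 3 and an at least 3.2-fold higher number (0.51 log units; beyond the scatter) from compound 1 to compound 4; the limit leaves it open whether they differ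

Going by these compounds, the true size of both isopropyl steps stays open, and so does whether the amide change has any effect at all on the isopropyl core. Also open, on these data alone, is whether an ethyl group on the aromatic nitrogen would give a measurable number in this assay, and what a simple amine such as piperidin-1-yl on the carbonyl carbon would do on either core.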